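The compounds below may be only part of what the source reports. "The series", "measured", "known", "first", "only" and "open" are said of these compounds alone.

Of the three measured compounds, compound 3 `CCCNC(=O)c1cc(Oc2ccc(NC(=O)c3cc4cccnc4n(-c4ccc(F)cc4)c3=O)cc2)ccn1` stands lowest: in a functional assay on HT-29 cells (Homo sapiens) for antiproliferative activity, read by MTT assay, with a stated time of 72 h (on this read-out lower numbers stand for stronger inhibition and higher numbers for weaker inhibition), compound 3 gives 84 nM. Compound 1 `CCNC(=O)c1cc(Oc2ccc(NC(=O)c3cc4cccnc4n(-c4ccc(F)cc4)c3=O)cc2)ccn1` gives 190 nM, and compound 2 `CCCNC(=O)c1cc(Oc2ccc(NC(=O)c3cc4cccnc4n(-c4ccccc4F)c3=O)cc2)ccn1` gives 200 nM. Both steps onto compound 3 are modest yet beyond the scatter: a 2.3-fold lower number from compound 1 to compound 3 (0.35 log units; beyond the scatter) and a 2.4-fold lower number from compound 2 to compound 3 (0.38 log units; beyond the scatter). Compound 4 `CCCNC(=O)c1cc(Oc2ccc(NC(=O)c3cc4cccnc4n(-c4ccc(Br)cc4F)c3=O)cc2)ccn1` differs from compound 3 by 4-bromo-2-fluorophenyl in place of 4-fluorophenyl on an aromatic nitrogen. For the measured compounds named here, only the second step bears on this, since it concerns the same ring on the aromatic nitrogen, and it ran against a 2-fluorophenyl; the added bromine has no measured precedent. A modest rise is therefore expected, and the step from compound 3 is expected to be a 1.8-fold higher number from compound 3 to compound 4 (0.25 log units; within the scatter). Compound 4 is expected to give 150 nM, between 60 nM and 400 nM.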

Compound 4, half-maximal inhibitory concentration: 2160 nM
Beside the measured number, compound 4's estimate is 14-fold (1.16 log units) below it, and the stated range ends below it.
By their numbers in this assay, from the lowest: compound 3; then compounds 1 and 2 (each within the scatter of the next); then compound 4.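

For the compounds shown here, the ring on the aromatic nitrogen tolerates far less than the earlier compounds suggested: 4-bromo-2-fluorophenyl in place of 4-fluorophenyl gives a 26-fold higher number from compound 3 to compound 4 (1.41 log units; beyond the scatter) in this assay, a large step where the fluorophenyl change alone had been modest. Bromo in place of hydrogen on an aromatic carbon of the 2-fluorophenyl ring is also large, with an 11-fold higher number from compound 2 to compound 4 (1.03 log units; beyond the scatter), so the bromine alone accounts for a large rise on that ring. Nothing available explains this rise.

From the compounds shown here alone, how 4-bromophenyl or 4-chloro-2-fluorophenyl would stand remains open, so it cannot be told whether the rise belongs to bromine itself or to its pairing with fluorine.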